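The compounds below may be only part of what the source reports. "The series", "measured", "known", "first", "only" and "open" are said of these compounds alone.

Working notes on the cinnamic acid series. The shared core carries a triazole whose aromatic nitrogen bears a varied aryl group. Compound 1, `COc1ccc(/C=C\C(=O)O)c(OCc2cn(-c3ccc(NC(=O)c4ccccc4)cc3)nn2)c1CC=C(C)C`, gives 23300 nM in a functional assay on T47D cells (Homo sapiens) for cytotoxicity, read by MTT assay, with a stated time of 24 h; a lower number here means a stronger inhibitor, a higher number a weaker inhibitor. Compound 2, `COc1ccc(/C=C\C(=O)O)c(OCc2cn(-c3ccccc3F)nn2)c1CC=C(C)C`, gives 11000 nM. Compound 3, `COc1ccc(/C=C\C(=O)O)c(OCc2cn(-c3cccc(C#N)c3)nn2)c1CC=C(C)C`, gives 19200 nM. Of the three numbers, compound 3 stands second highest; compound 1 is nearest, with a gap that lies within the scatter, and compound 2 is furthest, also within the scatter. Among the compounds with values here, the only single-point step measured so far runs a 1.7-fold higher number from compound 2 to compound 3 (0.24 log units; within the scatter).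

Compound 4, `COc1ccc(/C=C\C(=O)O)c(OCc2cn(-c3ccc(CO)cc3)nn2)c1CC=C(C)C`, is not yet measured. Relative to compound 3 the change is 4-(hydroxymethyl)phenyl in place of 3-cyanophenyl on an aromatic nitrogen, on the aromatic nitrogen of the triazole. Within the data shown here, the step from compound 2 to compound 3, itself within the scatter, is the one comparison bearing on an aryl swap at this position, and the values of compound 1, compound 2 and compound 3 all lie close together. No basis exists here for expecting a shift beyond the scatter in either direction. The expectation for compound 4 is therefore a step of a 1.1-fold lower number from compound 3 to compound 4 (0.03 log units; within the scatter) in this assay. The estimate for compound 4 is 18000 nM, with a range from 9000 nM to 36000 nM.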

Compound 4, half-maximal inhibitory concentration: 40000 nM
Estimate against measurement, compound 4: 2.2-fold (0.35 log units) below; the measured number lies above the stated range.
By their numbers in this assay, from the lowest: compounds 2, 3, 1 and 4 (each within the scatter of the next, the first and the last beyond it).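

In this assay, the aryl group on the aromatic nitrogen now produces differences that exceed the scatter. Within the data shown here, these are the 3-cyanophenyl to 4-(hydroxymethyl)phenyl change (a 2.1-fold higher number from compound 3 to compound 4 (0.32 log units; beyond the scatter)) and the 2-fluorophenyl to 4-(hydroxymethyl)phenyl change (a 3.6-fold higher number from compound 2 to compound 4 (0.56 log units; beyond the scatter)), whereas the only earlier step at this position stayed within it (a 1.7-fold higher number from compound 2 to compound 3 (0.24 log units; within the scatter)). Hydroxymethyl in place of benzamido on the aromatic carbon does not separate the two compounds (a 1.7-fold higher number from compound 1 to compound 4 (0.23 log units; within the scatter)), so the position responds to some aryl swaps and not to others, and no evidence is available here to explain the result.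

The step from compound 3 to compound 4 changes both the group and its place on the phenyl ring, so the contribution of each cannot be told apart from these compounds. From the compounds shown here alone, whether an aminomethyl group or a carboxylic acid in place of hydroxymethyl would give a number in line with compound 4 or one closer to compound 2 remains open.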